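This account rests on a few compounds, and the source may have more. Where it says the series, first, only, none or still open, it means among the compounds named here.

In an ADME assay on MDCK cells (Canis lupus familiaris) for cytotoxicity, read by MTT assay, with a stated time of 24 h (a lower number here means that less compound is tolerated, a higher number that more compound is tolerated), compound 1 `N#CCCN(Cc1cccs1)S(=O)(=O)c1ccc(Br)cc1` gives > 173000 nM, which is a limit and not a number. Compound 2 `CC(=O)c1ccc(S(=O)(=O)N(CCC#N)Cc2cccs2)cc1` gives > 191000 nM, also a limit. Compound 3 `N#CCCN(Cc1ccco1)S(=O)(=O)c1ccc(Br)cc1` gives > 180000 nM, again a limit, so it has no exact value to start from. Compound 4 `N#CCCN(Cc1ccco1)S(=O)(=O)c1ccc(C(F)(F)F)cc1` differs from compound 3 by one change: trifluoromethyl in place of bromo on an aromatic carbon. Going by the values given here, two measured steps bear on it: a step that the two limits leave unreadable from compound 1 to compound 2, which also replaces bromo on an aromatic carbon, and a step that the two limits leave unreadable from compound 1 to compound 3, which introduces the furan-2-yl group that compound 3 and compound 4 share. With no readable size to carry over, no step beyond the scatter is expected in this assay, and the expected step is a step that the limit leaves unreadable from compound 3 to compound 4. Compound 4 is estimated at 186000 nM, with an expected range from 100000 nM to 300000 nM.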

Compound 4, half-maximal cytotoxic concentration: > 186000 nM
Compound 4: no number, only a limit; the forecaster's own chance of this, stated with the estimate: 85%; the middle value sits exactly at the limit.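

In this assay compound 4 gives > 186000 nM, which is a limit, and the step to it from compound 3, also known only as a limit, cannot be read. The compounds shown leave open whether replacing bromo with trifluoromethyl changes the half-maximal cytotoxic concentration at all.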